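Hydrazone aryl swaps on a shared triazolylpyridine core

A few compounds are considered here, and "the series" means these few. Any claim that something is new, unique, unknown or untested is made for them only; others in the source may bear on it.

Measured compounds and their values:
compound 1, `CN(C)CCn1cnnc1-c1cc(Oc2ccc(NC(=O)N/N=C/c3ccc(O)c(Br)c3)cc2F)ccn1`, 1370 nM
compound 2, `CN(C)CCn1cnnc1-c1cc(Oc2ccc(NC(=O)N/N=C/c3c[nH]c4ccccc34)cc2F)ccn1`, 820 nM
compound 3, `CN(C)CCn1cnnc1-c1cc(Oc2ccc(NC(=O)N/N=C/c3ccccc3O[N+](=O)[O-])cc2F)ccn1`, 1200 nM

In a functional assay on A549 cells (Homo sapiens) for cytotoxicity, read by MTT assay, with a stated time of 72 h (a lower number here means a stronger inhibitor, a higher number a weaker inhibitor), compound 3 gives 1200 nM, which stands second highest of the three numbers. Its nearest neighbour is compound 1, and the two differ by a 1.1-fold lower number from compound 1 to compound 3 (0.06 log units; within the scatter). Among the compounds with values here, the step of a 1.5-fold higher number from compound 2 to compound 3 (0.17 log units; within the scatter) is also small, as is a 1.7-fold lower number from compound 1 to compound 2 (0.22 log units; within the scatter), so no compound here can be called the strongest or weakest.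

Compound 4, `Cc1cc(/C=N/NC(=O)Nc2ccc(Oc3ccnc(-c4nncn4CCN(C)C)c3)c(F)c2)cc(C)c1O`, has not yet been measured. It differs from compound 3 in one place: 4-hydroxy-3,5-dimethylphenyl in place of 2-(nitrooxy)phenyl on a carbon with a double bond to nitrogen. The measured steps that bear on this change are the three aryl swaps on the same carbon with a double bond to nitrogen, and all of them stayed within the scatter. Compound 1 already carries a hydroxyphenyl group at that position and its number sits close to compound 3. The expected step is therefore no change at the digits printed from compound 3 to compound 4 (within the scatter), no more than the scatter. Compound 4 is estimated at 1200 nM, with a range from 500 nM to 3000 nM.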

Compound 4, half-maximal inhibitory concentration: 1640 nM
For compound 4 the middle estimate is 1.4-fold (0.14 log units) below the measured one; low and high end bracket the measured number.
By their numbers in this assay, from the lowest: compounds 2, 3, 1 and 4 (each within the scatter of the next).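

In this assay, 4-hydroxy-3,5-dimethylphenyl entering in place of 2-(nitrooxy)phenyl on a carbon with a double bond to nitrogen gives a 1.4-fold higher number from compound 3 to compound 4 (0.14 log units; within the scatter), so a group with a hydrogen-bond donor and no nitrogen leaves the number within the scatter. The comparison with the other hydroxyphenyl group gives a 1.2-fold higher number from compound 1 to compound 4 (0.08 log units; within the scatter), and the widest gap now seen at this place, a 2.0-fold higher number from compound 2 to compound 4 (0.30 log units; within the scatter), also stays within the scatter, so four different aryl groups here cannot be told apart. No independent measurement bears on this result.

On these data alone, all four compounds carry an aromatic ring at this place, so it remains open whether a cyclohexyl ring or a carboxylic acid on a short alkyl chain would move the number beyond the scatter. As far as these compounds go, it is also open whether these aryl groups would stay alike with a morpholine in place of the dimethylamino group.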